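Trifluoromethyl in place of bromo on the shared core

This account rests on a few compounds, and the source may have more. Where it says the series, first, only, none or still open, it means among the compounds named here.

Among the measured compounds shown here, in a functional assay on A549 cells (Homo sapiens) for antiproliferative activity, read by MTT assay, with a stated time of 48 h (on this read-out higher numbers stand for weaker inhibition and lower numbers for stronger inhibition), compound 1 `Fc1ccc(-c2nn(-c3ccccc3)cc2-c2nc3ccccc3[nH]2)cc1` gives 1510 nM, and compound 2 `Fc1ccc(-c2nn(-c3ccccc3)cc2-c2nc3cc(Br)ccc3[nH]2)cc1` gives 5830 nM, the higher of the two numbers so far. Compound 3 `Fc1ccc(-c2nn(-c3ccccc3)cc2-c2nc3cc(C(F)(F)F)ccc3[nH]2)cc1` has trifluoromethyl in place of bromo on an aromatic carbon. For the measured compounds named here, one measured step bears on this carbon: a 3.9-fold higher number from compound 1 to compound 2 (0.59 log units; beyond the scatter), a modest step beyond the scatter, with bromo in place of hydrogen. Going by the values given here, no measured compound shows one group exchanged for another at this carbon, so the evidence on trifluoromethyl is indirect. Among the compounds with values here, with only that step from compound 1 as a guide, the number is expected to stay close to that of compound 2, with no shift beyond the scatter. The expected change is small: a 1.2-fold lower number from compound 2 to compound 3 (0.07 log units; within the scatter). In this assay the estimate for compound 3 is 5000 nM, with a range of 2000 nM to 12000 nM.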

Compound 3, half-maximal inhibitory concentration: 2340 nM
Compound 3: the middle estimate sits 2.1-fold (0.33 log units) above what was measured; the measured number falls inside the stated range.
By their numbers in this assay, from the lowest: compounds 1 and 3 (each within the scatter of the next); then compound 2.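

In this assay, this aromatic carbon separates the two substituents: trifluoromethyl in place of bromo gives a 2.5-fold lower number from compound 2 to compound 3 (0.40 log units; beyond the scatter), a modest step beyond the scatter, so the rise seen with bromo does not extend to every group placed here. Trifluoromethyl in place of hydrogen gives a 1.5-fold higher number from compound 1 to compound 3 (0.19 log units; within the scatter), which lies within the scatter, so in this assay the larger group at this carbon is not separated from hydrogen, and compound 2 alone stands apart. The data offer no measured basis for explaining the difference between bromo and trifluoromethyl.

Among the compounds shown here, with only three compounds, no trend across substituents at this carbon can be drawn. From the compounds shown here alone, whether an amine, a carboxylic acid or a nitrile here would read with compound 1 and compound 3 or with compound 2 remains open.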